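A few compounds are considered here, and "the series" means these few. Any claim that something is new, unique, unknown or untested is made for them only; others in the source may bear on it.

Working notes on a small set of anilide-linked amines profiled for agonist behaviour. In an assay on cells for agonist activity at D(4) dopamine receptor (Homo sapiens), read by luminescence and beta-arrestin recruitment, with a stated time of 90 min (on this read-out higher numbers stand for larger maximal responses and lower numbers for smaller maximal responses), compound 1 `Cc1ccc(C2CCN(CC(=O)Nc3cccc(C)c3)CC2)nc1` returns "not active" (no number reported) and compound 3 `Cc1cccc(NC(=O)CCN2CCN(c3ccccn3)CC2)c1` likewise returns "not active" (no number reported); neither carries a number. Within the data shown here, compound 2 `Cc1cccc(NC(=O)CN2CCN(c3ncccn3)CC2)c1` is the one member of the set with a recorded figure: in this assay compound 2 gives 24.7%, a small maximal response against the reference, and it therefore stands alone as the only quantified point, with nothing to rank it against.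

Compound 4 `Cc1cccc(NC(=O)CN2CCN(c3ccc(Cl)cn3)CC2)c1` is the next entry awaiting measurement. It keeps the whole of compound 2 apart from one substituent on the ring amine: 5-chloropyridin-2-yl in place of pyrimidin-2-yl on an amine nitrogen in a ring. Among the measured compounds shown here, no measured pair in the set differs in a single place, so there is no precedent step to draw on for this exchange.

The expectation is that compound 4 lands close to compound 2, with a step of a number 5.3 percentage points higher from compound 2 to compound 4 (within the scatter) that is not clearly beyond the scatter. In this assay compound 4 is accordingly estimated at 30%, within a range of 10% to 60%, with a real chance that only "not active" is returned.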

Compound 4, largest response reached (Emax), in percent of the reference or control that the assay uses: "not active" (no number reported)
For compound 4 the study gives words and no number; no gap can be computed for the estimate.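

Among these compounds, compound 4 carries words and no number in this assay, so no step from compound 2 to compound 4 can be read. No available evidence bears on this result. The compounds shown leave open how replacing pyrimidin-2-yl with 5-chloropyridin-2-yl changes the maximal response.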